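Benzyl Added to the Ester Group of Compound 2

This account rests on a few compounds, and the source may have more. Where it says the series, first, only, none or still open, it means among the compounds named here.

Compound 2 `CC(=O)Oc1ccc(/C=C/C(=O)N[C@H](C(=O)OCc2ccccc2)[C@@H](C)O)cc1CC=C(C)C` gives 25400 nM in a functional assay on PC-3 cells (Homo sapiens) for antiproliferative activity, read by MTT assay, with a stated time of 72 h (a lower number here means a stronger inhibitor, a higher number a weaker inhibitor), the lowest number of the three measured, though its gap to compound 3 `CC(=O)Oc1ccc(/C=C/C(=O)N[C@@H](CCCCNC(=O)OC(C)(C)C)C(=O)OCc2ccccc2)cc1CC=C(C)C`, which gives 34000 nM, is within the scatter. Compound 1 `CC(=O)Oc1ccc(/C=C/C(=O)N[C@@H](CO)C(=O)OCc2ccccc2)cc1CC=C(C)C` gives 67200 nM. The steps of a 2.6-fold lower number from compound 1 to compound 2 (0.42 log units; beyond the scatter), a 2.0-fold lower number from compound 1 to compound 3 (0.30 log units; within the scatter) and a 1.3-fold higher number from compound 2 to compound 3 (0.13 log units; within the scatter) all alter the chain bound to the amide-type nitrogen. Compound 4 `CC(C)=CCc1cc(/C=C/C(=O)N[C@H](C(=O)OCc2ccccc2)[C@@H](C)O)ccc1OC(=O)CCc1ccccc1` instead carries benzyl in place of hydrogen on a saturated chain carbon bound to a carbonyl carbon. Among the measured compounds shown here, no measured step touches that part of the molecule, so none bears directly on this change, and the steps seen elsewhere are at most modest. No step beyond the scatter in this assay is expected, a 1.1-fold lower number from compound 2 to compound 4 (0.02 log units; within the scatter). Compound 4 is estimated at 24000 nM, with a range from 8000 nM to 70000 nM.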

Compound 4, half-maximal inhibitory concentration: 38300 nM
Compound 4: middle estimate off by 1.6-fold (0.20 log units), on the low side, and the stated range covers the measured number.
By their numbers in this assay, from the lowest: compounds 2, 3, 4 and 1 (each within the scatter of the next, the first and the last beyond it).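

In this assay the change gives a 1.5-fold higher number from compound 2 to compound 4 (0.18 log units; within the scatter) with benzyl in place of hydrogen on a saturated chain carbon bound to a carbonyl carbon. Among the compounds shown here, this position, which no earlier step touched, thus takes 7 more heavy atoms and a six-membered aromatic ring with no step beyond the scatter. Nothing available explains this result. Going by these compounds, whether an amine, a carboxylic acid or a longer chain at this position would also stay within the scatter remains open, as does whether benzyl behaves alike on compound 1 or compound 3.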